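This account rests on a few compounds, and the source may have more. Where it says the series, first, only, none or still open, it means among the compounds named here.

Of the compounds shown here, two have so far been tested in a functional assay on A549 cells (Homo sapiens) for cytotoxicity, read by CCK-8 assay, with a stated time of 24 h; on this read-out lower numbers stand for stronger inhibition and higher numbers for weaker inhibition. Within the data shown here, compound 1 `C/C(=C\c1cc(C2=CCCCC2)co1)C(N)=O` is the first of them. In this assay compound 1 gives > 50000 nM, which is a limit of the assay and not a number. Compound 2 `C/C(=C\c1cc(-c2ccc(F)cc2)cs1)C(N)=O` is the second. In this assay compound 2 gives > 50000 nM, again a limit rather than a measured number. Compound 2 thus stands where every value shown stands, at the limit of > 50000 nM in this assay, at which 2 of the 2 values shown sit, and nothing in the data separates it from compound 1. Compound 3 `C=Cc1ccc(-c2csc(/C=C(\C)C(N)=O)c2)cc1` differs from compound 2 in one place: vinyl in place of fluoro on an aromatic carbon. Among the measured compounds shown here, no step between measured compounds has been recorded, so this change has no precedent in this assay. The values at the limit of > 50000 nM in this assay, at which 2 of the 2 values shown sit, give no hint of a direction. The step of a number no higher from compound 2 to compound 3 (the limit leaves the size open) is expected to be none beyond the scatter. Compound 3 is accordingly expected to show 50000 nM, within a range from 20000 nM to 120000 nM.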

Compound 3, half-maximal inhibitory concentration: > 50000 nM
Compound 3: no number, only a limit; the forecaster's own chance of this, stated with the estimate: 75%; the middle value sits exactly at the limit.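

No step can be read between compound 2 and compound 3, as each gives only a limit of the assay and not a number. The compounds shown leave open how vinyl and fluoro compare, and what any change would do to a measured value, with all of them resting at one limit: the limit of > 50000 nM in this assay, at which 3 of the 3 values shown sit.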